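This account rests on a few compounds, and the source may have more. Where it says the series, first, only, none or still open, it means among the compounds named here.

Measured so far in a functional assay on cells for antagonist activity at Oxytocin receptor (Homo sapiens), read by a beta-lactamase reporter; a higher number here means a weaker inhibitor, a lower number a stronger inhibitor:
compound 1 `CCN(C(=O)c1cnc(-c2ccccc2C)cn1)c1ccc(OC)nc1` gives 129 nM;
compound 2 `COc1ccc(N(C)C(=O)c2cnc(-c3ccc(F)cc3C)cn2)cn1` gives 218 nM.

Compound 1 carries the lower of the two numbers, but compound 2 sits within the usual scatter of it, so the two are not separated by this assay. Among the compounds with values here, no single-point step between measured compounds is available in this set, as compound 1 and compound 2 differ at more than one place.

Compound 3 `CCN(C(=O)c1cnc(-c2ccc(C#N)cc2C)cn1)c1ccc(OC)nc1` is the next case. Relative to compound 1 the change is cyano in place of hydrogen on an aromatic carbon of the shared core's pendant ring. Within the data shown here, with no measured precedent for this change, the expectation is a step of modest size, probably toward a somewhat lower number, though a step within the scatter would not be surprising. The expected step of a 1.3-fold lower number from compound 1 to compound 3 (0.11 log units; within the scatter) is estimated accordingly. For compound 3 the estimate is 100 nM, with a range from 30 nM to 350 nM.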

Compound 3, inhibition constant: 393 nM
Compound 3: middle estimate off by 3.9-fold (0.59 log units), on the low side, outside the stated range (above it).
By their numbers in this assay, from the lowest: compounds 1, 2 and 3 (each within the scatter of the next, the first and the last beyond it).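

In this assay, within the data shown here, cyano in place of hydrogen on the aromatic carbon para to a large group gives a 3.0-fold higher number from compound 1 to compound 3 (0.48 log units; beyond the scatter), the only single-point step so far. This position on the pendant ring therefore responds to substitution: going from 2-methylphenyl to 4-cyano-2-methylphenyl costs inhibitory strength by more than the scatter. Nothing on hand gives a reason for this step.

On these data alone, whether the loss is specific to cyano or extends to other groups on this carbon remains open, since the fluorine at this place in compound 2 comes with a second difference from compound 1 and cannot be read as a single change. A methoxy, an amine or a carboxylic acid on the same carbon would help separate these possibilities.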